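This account rests on a few compounds, and the source may have more. Where it says the series, first, only, none or still open, it means among the compounds named here.

Compound 1 `COc1ccc(Cc2nnc(NC(=O)/C(C#N)=C/c3ccccc3OS(=O)(=O)c3ccc([N+](=O)[O-])cc3)s2)cc1`: 17%
Compound 2 `COc1ccc(Cc2nnc(NC(=O)/C(C#N)=C/c3ccccc3OS(=O)(=O)c3ccc(Cl)cc3)s2)cc1`: 34%

In an ADME assay on HEK-293T cells (Homo sapiens) for inhibition, read by CCK-8 assay, with a stated time of 48 h, tested at 20 uM (on this read-out higher numbers stand for more inhibition of growth at the one concentration tested and lower numbers for less inhibition of growth), compound 1 gives 17%, the lower of the two measured numbers. Compound 2 gives 34%, reached by a number 17 percentage points higher from compound 1 to compound 2 (beyond the scatter). Compound 3, `N#C/C(=C\c1ccccc1OS(=O)(=O)c1ccc([N+](=O)[O-])cc1)C(=O)Nc1nnc(Cc2cccc3ccccc23)s1`, is not yet measured; it differs from compound 1 at a different site: naphthalen-1-yl in place of 4-methoxyphenyl on a saturated chain carbon bound to an aromatic carbon. Going by the values given here, the only measured step swaps the nitro group at the far end of the molecule and leaves the 4-methoxybenzyl untouched, so it gives no guide to what replacing 4-methoxyphenyl with naphthalen-1-yl does. Among the compounds with values here, with no step bearing on this change, the expectation is a number near compound 1, with any shift likely within the usual scatter of this assay. Compound 3 is therefore estimated at 22%, in a range from 5% to 42%, which corresponds to an expected step of a number 5 percentage points higher from compound 1 to compound 3 (within the scatter).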

Compound 3, percent growth inhibition at one concentration: 25%
Estimate against measurement, compound 3: 3 percentage points below; measured number inside the range.
By their numbers in this assay, from the lowest: compounds 1, 3 and 2 (each within the scatter of the next, the first and the last beyond it).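

In this assay, exchanging the 4-methoxybenzyl group for a (naphthalen-1-yl)methyl group gives a number 8 percentage points higher from compound 1 to compound 3 (within the scatter) and so does not separate the two compounds. Going by these compounds alone, this is the first look at this site: with the nitro group held constant, a second six-membered aromatic ring can enter and the methoxy oxygen can leave without a change that stands clear of the scatter. No measured evidence bears on the reason for this result.

The compounds shown leave open how naphthalen-1-yl would read with chloro in place of nitro, so it is unknown whether the two sites act independently. They also leave open what an amine or a carboxylic acid at this place would do to the reading.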